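Geranyl ether in place of trifluoroethyl on a cyclopropane hydrazide

The source may report more compounds than this note shows. Statements on the series, on what has been measured and on what is new or still open speak of the compounds shown alone.

This account follows a cyclopropane hydrazide series tested in a functional assay on MCF7 cells (Homo sapiens) for inhibition, read by MTT assay, with a stated time of 72 h; on this read-out lower numbers stand for stronger inhibition and higher numbers for weaker inhibition. Compound 1 `CCOc1ccc(C2CC2C(=O)NNC(=O)c2ccncc2)cc1` and compound 3 `CCOc1ccc(C2CC2C(=O)NNc2nncc3ccccc23)cc1` belong to the same set, yet compound 1 gives "not determined" (no result reported) and compound 3 gives "not determined" (no result reported) in this assay, so neither carries a number. Within the data shown here, compound 2 `O=C(NNc1nncc2ccccc12)C1CC1c1ccc(OCC(F)(F)F)cc1` therefore stands alone: in this assay compound 2 gives 8000 nM, the only figure the set shows, and no step between two measured compounds is available.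

Compound 4 `CC(C)=CCC/C(C)=C/COc1ccc(C2CC2C(=O)NNc2nncc3ccccc23)cc1` is the next member, and it differs from compound 2 in one place: 2,6-dimethylhepta-1,5-dien-1-yl in place of trifluoromethyl on a saturated chain carbon bound to an oxygen on an aromatic ring. Among the measured compounds shown here, with no comparable step among the measured compounds, the expected change from compound 2 to compound 4 is set at none beyond the usual scatter, a 1.3-fold lower number from compound 2 to compound 4 (0.12 log units; within the scatter), with wide uncertainty in either direction. On that basis compound 4 is estimated to give 6000 nM in this assay, within an expected range from 1500 nM to 25000 nM.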

Compound 4, half-maximal inhibitory concentration: 23000 nM
The estimate for compound 4 lay 3.8-fold (0.58 log units) below the measured number; low and high end bracket the measured number.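

This gives the series its first readable step: in this assay, the change from trifluoromethyl to 2,6-dimethylhepta-1,5-dien-1-yl produces a 2.9-fold higher number from compound 2 to compound 4 (0.46 log units; beyond the scatter). The position on a saturated chain carbon bound to an oxygen on an aromatic ring therefore responds to this change, modestly, and the larger group, with 9 heavy atoms against 4 and 2 double bonds, goes with weaker inhibition. No supporting data are available to explain this shift.

Steps involving compound 1 or compound 3 cannot be read, so the ethoxy group of compound 3 cannot be placed relative to the two ethers with numbers. Open too, going by these compounds, is how an amine or a carboxylic acid at the end of the ether chain would compare with either group.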